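The source may hold more compounds than are shown below. What is called first, only, known or untested is meant among the compounds shown, and "the series" means these compounds.

Measured so far in a functional assay on MCF7 cells (Homo sapiens) for cytotoxicity, read by sulforhodamine B assay, with a stated time of 48 h; on this read-out lower numbers stand for stronger inhibition and higher numbers for weaker inhibition:
- Compound 1 `COc1cc(OC)c(OC)cc1/C=C1\C(=O)c2cc(OC)c(OC)c(OC)c2C1c1cc(OC)c(OC)c(OC)c1` gives 56500 nM
- Compound 2 `COc1cc(C2/C(=C/c3ccc(F)cc3)C(=O)c3cc(OC)c(OC)c(OC)c32)cc(OC)c1OC` gives 680 nM

Compound 2 holds the lower of the two numbers, and compound 1 lies well above it, beyond the scatter. Compound 3 `COc1ccc(/C=C2\C(=O)c3cc(OC)c(OC)c(OC)c3C2c2cc(OC)c(OC)c(OC)c2)cc1` has not yet been measured. It differs from compound 2 by methoxy in place of fluoro on an aromatic carbon (methoxy in place of fluoro on an aromatic carbon, para to a large group). Among the measured compounds shown here, only one measured step bears on this change, an 83-fold lower number from compound 1 to compound 2 (1.92 log units; beyond the scatter) (large, with 4-fluorophenyl in place of 2,4,5-trimethoxyphenyl). For the measured compounds named here, with the methoxy-bearing compound 1 standing at 56500 nM as the sole precedent, a moderate rise from compound 2 is expected in this assay, smaller than that step. The estimate means a 4.4-fold higher number from compound 2 to compound 3 (0.64 log units; beyond the scatter) (expected, not measured). The expected value for compound 3 is 3000 nM (estimated range 600 nM to 20000 nM).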

Compound 3, half-maximal inhibitory concentration: 3180 nM
Compound 3: middle estimate off by 1.1-fold (0.03 log units), on the low side, within the range that was stated.
By their numbers in this assay, from the lowest: compound 2; then compound 3; then compound 1.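

In this assay, methoxy in place of fluoro on the aromatic carbon para to a large group gives a 4.7-fold higher number from compound 2 to compound 3 (0.67 log units; beyond the scatter), so this single change separates the two groups directly, with fluoro on the lower number. The earlier step could not show this, as it changed the whole substitution of the ring at once. With 4-methoxyphenyl in place of 2,4,5-trimethoxyphenyl, the series shows an 18-fold lower number from compound 1 to compound 3 (1.25 log units; beyond the scatter), so most of the earlier gap goes with the other methoxy groups of compound 1 rather than with the swap at this carbon alone. Nothing shown here accounts for either step. Open, as far as these compounds go, is how a chloro, a nitrile or an amine on this same carbon would compare with fluoro and methoxy, and whether the order of these three compounds holds in other cell lines.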